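The source may report more compounds than this note shows. Statements on the series, on what has been measured and on what is new or still open speak of the compounds shown alone.

Measured compounds:
- compound 1, `c1ccc(Oc2ccc3c(NCCCNCc4ccco4)ccnc3c2)cc1`, giving 15200 nM
- compound 2, `COc1ccc(F)cc1CNCCCNc1ccnc2cc(CC(C)C)ccc12`, giving 2900 nM

Both compounds were tested in an ADME assay on HepG2 cells (Homo sapiens) for cytotoxicity, read by luminescence, CellTiter-Glo and ATP content, with a stated time of 72 h; a higher number here means that more compound is needed for the effect, a lower number that less compound is needed. Compound 1, with its value of 15200 nM, has the highest of the two numbers measured; the nearest number comes from compound 2, whose value of 2900 nM is lower by a margin beyond the usual scatter of repeated measurements. For the measured compounds named here, compound 2 also carries a different side chain and a different group on the shared core, so its number speaks only for itself and sets no step for the change considered here.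

Going by the values given here, the unmeasured compound 3, `COc1ccc(-c2ccc3c(NCCCNCc4ccco4)ccnc3c2)cc1`, keeps the side chain of compound 1 and alters only one group on the core: 4-methoxyphenyl in place of phenoxy on an aromatic carbon. Among the compounds with values here, no measured pair shows this exact exchange, so the size and direction of its effect in this assay are not known from the data. The step from compound 1 to compound 3 is expected to be small, a 1.5-fold lower number from compound 1 to compound 3 (0.18 log units; within the scatter), likely within the scatter or only slightly beyond it toward a lower number. Compound 3 is therefore estimated at 10000 nM, with a range from 3000 nM to 30000 nM.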

Compound 3, half-maximal effective concentration: 6000 nM
Compound 3: middle estimate off by 1.7-fold (0.22 log units), on the high side; the measured number falls inside the stated range.
By their numbers in this assay, from the lowest: compound 2; then compound 3; then compound 1.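

In this assay the exchange gives a 2.5-fold lower number from compound 1 to compound 3 (0.40 log units; beyond the scatter) and so shows that this place on the core responds to the group it carries. The earlier compounds shown here could not show this, as they differed in more than one place and so gave no step at all. Phenoxy and 4-methoxyphenyl each hold one six-membered aromatic ring of carbon only and match in their counts of hydrogen-bond donors and acceptors, so a modest change in the number can arise here without any change in those counts, and no measurement at hand accounts for the shift.

The exchange also alters two things at once: in phenoxy an oxygen joins the ring to the core, whereas in 4-methoxyphenyl the ring is joined directly and carries a methoxy group, and this single pair cannot tell which of these matters. Plain phenyl at this place would help to separate the two, while a morpholine or a carboxylic acid would test whether an aromatic ring is needed here at all.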